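The source may hold more compounds than are shown below. What is called first, only, known or untested is meant among the compounds shown, and "the series" means these compounds.

Among the compounds with values here, in a functional assay on COLO 320 cells (Homo sapiens) for cytotoxicity, read by WST assay, with a stated time of 72 h (on this read-out lower numbers stand for stronger inhibition and higher numbers for weaker inhibition), compound 1 `O=[N+]([O-])c1ccc(-c2cc(-c3ccc4[nH]ccc4c3)on2)cc1` gives 14000 nM, the lower of the two numbers measured so far. Within the data shown here, compound 2 `COc1cccc(-c2cc(-c3cc4ccccc4n3C)no2)c1` gives 69500 nM in this assay; its structure differs from compound 1 in more than one place, so the two values show only that compound 2 sits higher. Compound 3 `COc1ccc(-c2cc(-c3ccc4[nH]ccc4c3)on2)cc1` remains to be measured. It arises from compound 1 by a single change, (methoxy in place of nitro on an aromatic carbon), on an aromatic carbon of a six-membered aromatic ring of carbon only, para to a large group. Among the measured compounds shown here, no step between measured compounds mirrors this exchange. Compound 2 also carries a methoxy and gives 69500 nM; on this basis a moderate rise in the number is expected for compound 3, though compound 2 differs in more than this one place. Compound 3 is estimated at 25000 nM in this assay, within 8000 nM to 80000 nM. The expected step is a 1.8-fold higher number from compound 1 to compound 3 (0.25 log units; within the scatter).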

Compound 3, half-maximal inhibitory concentration: 13500 nM
The estimate for compound 3 lay 1.9-fold (0.27 log units) above the measured number; low and high end bracket the measured number.
By their numbers in this assay, from the lowest: compounds 3 and 1 (each within the scatter of the next); then compound 2.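

In this assay, putting methoxy in place of nitro on this aromatic carbon, para to a large group, gives a 1.0-fold lower number from compound 1 to compound 3 (0.02 log units; within the scatter). This read-out therefore does not separate the two groups at this position, although they differ in heavy atoms, in hydrogen-bond acceptors and in the double bond outside aromatic rings. Compound 2 could not show this, as it differs from compound 1 in more than one place. Nothing among the data given accounts for this result.

On these data alone, whether an amine, a carboxylic acid or a longer chain such as butoxy on the same carbon would also stay within the scatter remains open. As far as these compounds go, it is also open whether methoxy and nitro would match each other on another carbon of this ring.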